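The source may report more compounds than this note shows. Statements on the series, on what has been measured and on what is new or still open speak of the compounds shown alone.

In a functional assay on HeLa cells (Homo sapiens) for antiproliferative activity, read by MTT assay, with a stated time of 72 h (a higher number here means a weaker inhibitor, a lower number a stronger inhibitor), compound 1 `NC1CCc2nc(-c3ccncc3)nc(Nc3cccc(F)c3)c2C1` gives 17000 nM, compound 2 `N[C@@H]1CCc2nc(-c3ccncc3)nc(Nc3cccc(F)c3)c2C1` gives 21800 nM and compound 3 `COc1cccc(Nc2nc(-c3ccncc3)nc3c2CC(N)CC3)c1` gives 17200 nM, so compound 2 stands within the scatter of both others. Compound 4 `N[C@H]1CCc2nc(-c3ccncc3)nc(Nc3cccc(F)c3)c2C1` follows from compound 2: the two compounds have the same atoms and bonds and differ only in configuration as drawn: 1 of 1 stereo elements differ; a stereocentre at a saturated ring carbon is drawn R in compound 2 and S in compound 4. The step bearing most directly on this change is a 1.3-fold higher number from compound 1 to compound 2 (0.11 log units; within the scatter), which comes with the fact that one of compounds 1 and 2 is drawn with a defined configuration and the other without, at the place where they differ. The step of a 1.0-fold higher number from compound 1 to compound 3 (0.01 log units; within the scatter), methoxy in place of fluoro on an aromatic carbon, concerns a different change and is equally small. No step beyond the scatter is therefore expected in this assay for this inversion. The expected step is a 1.4-fold lower number from compound 2 to compound 4 (0.13 log units; within the scatter). For compound 4 the estimate is 16000 nM, with an expected range of 8000 nM to 30000 nM.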

Compound 4, half-maximal inhibitory concentration: 17100 nM
The estimate for compound 4 lay 1.1-fold (0.03 log units) below the measured number; low and high end bracket the measured number.
By their numbers in this assay, from the lowest: compounds 1, 4, 3 and 2 (each within the scatter of the next).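

In this assay, the two drawn configurations at the stereocentre at a saturated ring carbon can now be compared directly, giving a 1.3-fold lower number from compound 2 to compound 4 (0.11 log units; within the scatter). Against the compound drawn without a configuration, the second form gives a 1.0-fold higher number from compound 1 to compound 4 (0.00 log units; within the scatter). Across compounds 1, 2 and 4, the configuration at this carbon therefore does not separate the numbers, which compound 2 alone could not show.

Going by these compounds, compound 3, with methoxy in place of fluoro, is drawn without a configuration, so inversion in that compound remains open. Also open, on these data alone, is whether inversion stays within the scatter with an acetamide or a dimethylamino group in place of the amine.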